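This account rests on a few compounds, and the source may have more. Where it says the series, first, only, none or still open, it means among the compounds named here.

Measured so far in a toxicity assay on HepG2 cells (Homo sapiens) for inhibition, read by CellTiter-Glo, with a stated time of 48 h; a higher number here means a weaker inhibitor, a lower number a stronger inhibitor:
compound 1 `COc1ccc2nc(C)cc(OCC(=O)Nc3ccc(Br)c(C)c3)c2c1`: 15900 nM
compound 2 `COc1ccc2nc(C)cc(OCC(=O)Nc3nc(C)c(C)s3)c2c1`: > 100000 nM

For compound 2 this assay returns only a limit, (the limit of > 100000 nM in this assay, at which 1 of the 2 values shown sits), so its position is known just as being at or beyond that value. Compound 3 `COc1ccc2nc(C)cc(OCC(=O)NNC(=O)c3ccncc3)c2c1` arises from compound 2 by ((pyridin-4-yl)carbonyl)amino in place of 4,5-dimethyl-1,3-thiazol-2-yl on an amide-type nitrogen. For the measured compounds named here, the one measured step on this nitrogen, an at least 6.2-fold higher number from compound 1 to compound 2 (0.79 log units; beyond the scatter), changed the same position and moved the value up to the limit; it says nothing about whether a further swap at this position moves the number back down, and no step to a hydrazide-type group has been measured. Compound 3 is therefore expected to stay near the limit, with an expected step of a number no higher from compound 2 to compound 3 (the limit leaves the size open) that cannot be resolved beyond the scatter. The estimate for compound 3 in this assay is 100000 nM, within a range of 30000 nM to 300000 nM, most likely again reported as a limit.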

Compound 3, half-maximal inhibitory concentration: > 100000 nM
Compound 3 ended at the assay's limit; the forecaster's own chance of this, stated with the estimate: 60%; the middle value sits exactly at the limit.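

In this assay the result for compound 3 is a limit and not a number: the limit of > 100000 nM in this assay, at which 2 of the 3 values shown sit. A second, different group on this amide-type nitrogen, ((pyridin-4-yl)carbonyl)amino, also gives an at least 6.2-fold higher number from compound 1 to compound 3 (0.79 log units; beyond the scatter), so among the compounds shown 4-bromo-3-methylphenyl remains the only group with a readable value. The step between compound 2 and compound 3 cannot be read, so 4,5-dimethyl-1,3-thiazol-2-yl and ((pyridin-4-yl)carbonyl)amino cannot be ordered against each other.

Open, as far as these compounds go, is which part of 4-bromo-3-methylphenyl goes with the readable value, for instance whether an unsubstituted phenyl or a 4-chlorophenyl on this nitrogen would also return a number. Also open, from the compounds shown here alone, is whether a benzyl group or a longer alkyl chain at this position would return a number.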